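A few compounds are considered here, and "the series" means these few. Any claim that something is new, unique, unknown or untested is made for them only; others in the source may bear on it.

In a functional assay on DU-145 cells (Homo sapiens) for antiproliferative activity, read by propidium iodide staining, with a stated time of 96 h (on this read-out lower numbers stand for stronger inhibition and higher numbers for weaker inhibition), three compounds sharing one core have been measured. Compound 1 `CC(O)(CS(=O)(=O)c1ccc(F)cc1)C(=O)Nc1ccc(S(F)(F)(F)(F)F)cc1` gives 27700 nM, compound 2 `CC(O)(CS(=O)(=O)c1ccccc1C(F)(F)F)C(=O)Nc1ccc(S(F)(F)(F)(F)F)cc1` gives 29400 nM, and compound 3 `CC(O)(CS(=O)(=O)c1ccc(OC(F)(F)F)cc1)C(=O)Nc1ccc(S(F)(F)(F)(F)F)cc1` gives 39300 nM. Compound 3 therefore stands level with the other two, within the scatter of both, as a 1.4-fold higher number from compound 1 to compound 3 (0.15 log units; within the scatter) and a 1.3-fold higher number from compound 2 to compound 3 (0.13 log units; within the scatter) show.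

The next case is compound 4 `CC(O)(CS(=O)(=O)c1ccccc1OC(F)(F)F)C(=O)Nc1ccc(S(F)(F)(F)(F)F)cc1`. The change is 2-(trifluoromethoxy)phenyl in place of 4-(trifluoromethoxy)phenyl on a sulfonyl sulfur, with the same atoms joined differently. Among the compounds with values here, no measured pair isolates such a rearrangement, so the evidence is indirect. Putting 2-(trifluoromethyl)phenyl in place of 4-fluorophenyl gave a 1.1-fold higher number from compound 1 to compound 2 (0.03 log units; within the scatter). The step that brings in 4-(trifluoromethoxy)phenyl in place of 2-(trifluoromethyl)phenyl is the closest to the present change, and it remains small at a 1.3-fold higher number from compound 2 to compound 3 (0.13 log units; within the scatter). These steps, like a 1.4-fold higher number from compound 1 to compound 3 (0.15 log units; within the scatter), all stay within the scatter, so no change beyond it is expected in this assay, and no direction can be firmly expected. The estimated step is a 1.2-fold lower number from compound 3 to compound 4 (0.08 log units; within the scatter). For compound 4 the estimated value is 33000 nM, with an expected range from 18000 nM to 58000 nM.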

Compound 4, half-maximal inhibitory concentration: 19500 nM
Beside the measured number, compound 4's estimate is 1.7-fold (0.23 log units) above it; the measured number falls inside the stated range.
By their numbers in this assay, from the lowest: compounds 4, 1, 2 and 3 (each within the scatter of the next).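

Within the data shown here, compound 3 and compound 4 have the same atoms joined differently, so this pair isolates where the trifluoromethoxy group sits on the aromatic ring on the sulfonyl sulfur, which no earlier pair did. In this assay, 2-(trifluoromethoxy)phenyl in place of 4-(trifluoromethoxy)phenyl gives a 2.0-fold lower number from compound 3 to compound 4 (0.30 log units; within the scatter) and thus does not clearly separate the two isomers, while trifluoromethoxy in place of trifluoromethyl on an aromatic carbon gives a 1.5-fold lower number from compound 2 to compound 4 (0.18 log units; within the scatter) and 2-(trifluoromethoxy)phenyl in place of 4-fluorophenyl gives a 1.4-fold lower number from compound 1 to compound 4 (0.15 log units; within the scatter) as the remaining comparisons with the new compound. All four compounds therefore remain level within the scatter of one another at this place, and nothing measured here accounts for any of these small steps.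

The compounds shown leave open whether an amine or a carboxylic acid on the aromatic ring would carry the number beyond the scatter, since every group shown at this place bears fluorine. They also leave open what a longer chain in place of the aromatic ring on the sulfonyl sulfur would do in this assay on the otherwise unchanged core.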